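The source may report more compounds than this note shows. Statements on the series, on what has been measured and on what is new or still open speak of the compounds shown alone.

Compound 1 `O=C(NNS(=O)(=O)c1ccccc1C(F)(F)F)c1cc2cc(Cl)ccc2[nH]1`: 800 nM
Compound 2 `Cc1cccc(S(=O)(=O)NNC(=O)c2cc3cc(Cl)ccc3[nH]2)c1`: 1200 nM

Both numbers come from an assay on isolated protein for inhibition of branched-chain-amino-acid aminotransferase, cytosolic (Homo sapiens); on this read-out higher numbers stand for weaker inhibition and lower numbers for stronger inhibition. Compound 2 gives the higher of the two numbers, but the gap to compound 1 lies within the usual scatter, so the two cannot be told apart. Compound 3 `O=C(NNS(=O)(=O)c1ccccc1Cl)c1cc2cc(Cl)ccc2[nH]1` has not yet been measured; it differs from compound 2 by 2-chlorophenyl in place of 3-methylphenyl on a sulfonyl sulfur. Among the measured compounds shown here, no measured pair shows this change, so only a modest step is expected in this assay, in either direction or none beyond the scatter, estimated as a 1.3-fold lower number from compound 2 to compound 3 (0.12 log units; within the scatter). Compound 3 is expected to give about 900 nM, between 300 nM and 2700 nM.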

Compound 3, half-maximal inhibitory concentration: 5700 nM
Compound 3: the middle estimate sits 6.3-fold (0.80 log units) below what was measured; measured number above the stated range.
By their numbers in this assay, from the lowest: compounds 1 and 2 (each within the scatter of the next); then compound 3.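

The result in this assay shows that the group on a sulfonyl sulfur can change the number beyond the scatter: 2-chlorophenyl in place of 3-methylphenyl gives a 4.8-fold higher number from compound 2 to compound 3 (0.68 log units; beyond the scatter) in this series. Chloro in place of trifluoromethyl on an aromatic carbon gives a 7.1-fold higher number from compound 1 to compound 3 (0.85 log units; beyond the scatter) and so marks the trifluoromethyl of compound 1 as the better of these two groups here. No measurement at hand explains either step. As far as these compounds go, it remains open how a methoxy group or an amine in place of that chloro would read.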